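Thiazolylmethyl in place of thiadiazolylmethyl on the ring nitrogen

The source may hold more compounds than are shown below. What is called first, only, known or untested is meant among the compounds shown, and "the series" means these compounds.

In a functional assay on HepG2 cells (Homo sapiens) for inhibition, read by MTT assay, with a stated time of 48 h, tested at 2 uM (on this read-out lower numbers stand for less inhibition and higher numbers for more inhibition at the one concentration tested (going by the name of the read-out)), compound 1 `Cc1noc(C)c1-c1ccc2c(c1)C(c1ccccc1)NC(=O)N2C` gives 32.5%, compound 2 `Cc1noc(C)c1-c1ccc2c(c1)C(c1ccccc1)N(Cc1nnc(-c3ccccc3)s1)C(=O)N2C` gives 35.2%, and compound 3 `Cc1nc(-c2ccc(F)cc2)sc1CN1C(=O)N(C)c2ccc(-c3c(C)noc3C)cc2C1c1ccccc1` gives 26.4%. Compound 2 holds the highest of the three numbers, but its gap to compound 1 and to compound 3 both lie within the scatter, so no order is read from them. Among the measured compounds shown here, the only single-site step, a number 2.7 percentage points higher from compound 1 to compound 2 (within the scatter), is itself within the scatter. Compound 4 `Cc1noc(C)c1-c1ccc2c(c1)C(c1ccccc1)N(Cc1csc(-c3ccc(F)cc3)n1)C(=O)N2C` differs from compound 2 by 2-(4-fluorophenyl)-1,3-thiazol-4-yl in place of 5-phenyl-1,3,4-thiadiazol-2-yl on a saturated chain carbon bound to an amide-type nitrogen in a ring. For the measured compounds named here, no measured step addresses this exchange of one aryl-substituted heteroarylmethyl for another; compound 3 merely shows that a related fluorophenyl-thiazolylmethyl substituent on this core sits within the scatter of compound 2. A step no larger than the scatter is therefore expected, a number 4.2 percentage points lower from compound 2 to compound 4 (within the scatter), and compound 4 is estimated at 31%, between 19% and 43%.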

Compound 4, a percentage reported as inhibition, at one concentration (the size of the read-out at that concentration, not a potency): 31.3%
Compound 4: middle estimate off by 0.3 percentage points, on the low side; low and high end bracket the measured number.
By their numbers in this assay, from the lowest: compounds 3, 4, 1 and 2 (each within the scatter of the next).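

In this assay, 2-(4-fluorophenyl)-1,3-thiazol-4-yl in place of 5-phenyl-1,3,4-thiadiazol-2-yl on the saturated chain carbon gives a number 3.9 percentage points lower from compound 2 to compound 4 (within the scatter). Among the compounds shown here, the exchange of one aryl-substituted heteroaryl for another at this place therefore produces no step beyond the scatter, which the earlier compounds did not test directly. No available evidence bears on this result. Still open, as far as these compounds go, is whether a carboxylic acid or an amine on the aromatic end group, or a longer chain on the amide-type nitrogen in the ring, would give a step beyond the scatter.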